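The source may hold more compounds than are shown below. What is called first, only, known or untested is meant among the compounds shown, and "the series" means these compounds.

Measured compounds in a functional assay on Shh Light II cells (Mus musculus) for inhibition, read by a luciferase reporter; a higher number here means a weaker inhibitor, a lower number a stronger inhibitor:
- compound 1 `O=C(Nc1ccccc1Cl)N1CCC(c2nc(-c3ccc4ccccc4n3)no2)CC1` gives 510 nM
- compound 2 `O=C(CC1CCCCCC1)N1CCC(c2nc(-c3ccc4ccccc4n3)no2)CC1` gives 840 nM
- compound 3 `COc1ccccc1N(C)C(=O)N1CCC(c2nc(-c3ccc4ccccc4n3)no2)CC1` gives 3100 nM

Compound 3 stands at the highest of the three numbers. Its nearest neighbour is compound 2, from which a 3.7-fold higher number from compound 2 to compound 3 (0.57 log units; beyond the scatter) is found, a modest step beyond the scatter; its furthest is compound 1, with a 6.1-fold higher number from compound 1 to compound 3 (0.78 log units; beyond the scatter), likewise modest but beyond the scatter. Between compound 1 and compound 2 the step of a 1.6-fold higher number from compound 1 to compound 2 (0.22 log units; within the scatter) stays within the scatter.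

The next compound, compound 4 `Cc1noc(C)c1NC(=O)N1CCC(c2nc(-c3ccc4ccccc4n3)no2)CC1`, differs from compound 3 in one place: (3,5-dimethyl-1,2-oxazol-4-yl)amino in place of (2-methoxyphenyl)(methyl)amino on a carbonyl carbon.

Within the data shown here, two measured steps bear on this change. Among the measured compounds shown here, both steps that reach compound 3 go to a higher number, and compound 1, the one other compound in which the carbonyl carries an amino substituent, sits at the lower end of the series. Compound 4 carries a five-membered aromatic ring in place of the six-membered one and brings back a hydrogen-bond donor; on this basis compound 4 is expected to return to a lower number than compound 3, with an expected step of a 4.4-fold lower number from compound 3 to compound 4 (0.65 log units; beyond the scatter). Compound 4 is therefore estimated at 700 nM, within a range of 250 nM to 2500 nM.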

Compound 4, half-maximal inhibitory concentration: 3000 nM
Compound 4: middle estimate off by 4.3-fold (0.63 log units), on the low side; measured number outside the range, above it.
By their numbers in this assay, from the lowest: compounds 1 and 2 (each within the scatter of the next); then compounds 4 and 3 (each within the scatter of the next).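

In this assay the step of a 1.0-fold lower number from compound 3 to compound 4 (0.01 log units; within the scatter) shows that at this carbonyl carbon, (3,5-dimethyl-1,2-oxazol-4-yl)amino and (2-methoxyphenyl)(methyl)amino cannot be told apart, so the return of the amide hydrogen is not enough on its own to reach the level of compound 1. With that hydrogen kept, the step of a 5.9-fold higher number from compound 1 to compound 4 (0.77 log units; beyond the scatter) separates the 3,5-dimethyl-1,2-oxazol-4-yl from the 2-chlorophenyl on the amide-type nitrogen, while cycloheptylmethyl, with no such hydrogen, still gives the step of a 3.6-fold higher number from compound 2 to compound 4 (0.55 log units; beyond the scatter) and so goes against any link between that hydrogen and the lower numbers. Nothing on hand accounts for these differences.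

As far as these compounds go, whether (2-methoxyphenyl)amino would fall with compound 1 or with compound 3 remains open. So does the place of phenylamino, which would show what the chlorine contributes.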